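A few compounds are considered here, and "the series" means these few. Any claim that something is new, unique, unknown or untested is made for them only; others in the source may bear on it.

Measured so far:
Compound 1 `Cn1c(-c2ccc(NC(=O)CN3CCCC3)cc2)nc2cc(C(F)(F)F)ccc21`, in an ADME assay on MDBK cells (Bos taurus) for cytotoxicity, read by MTT assay, with a stated time of 96 h (a higher number here means that more compound is tolerated, a lower number that less compound is tolerated), compound 1 gives 65000 nM.
Compound 2 `CC(=O)Nc1ccc(-c2nc3cc(C(F)(F)F)ccc3[nH]2)cc1`, compound 2 gives 50000 nM.
Compound 3 `O=C(CCl)Nc1ccc(-c2nc3cc(C(F)(F)F)ccc3[nH]2)cc1`, compound 3 gives 17000 nM.

Compound 3 stands lowest of the three numbers in this assay, with compound 2 nearest and compound 1 furthest. Compound 4 `O=C(CN1CCCC1)Nc1ccc(-c2nc3cc(C(F)(F)F)ccc3[nH]2)cc1` differs from compound 3 in one place: pyrrolidin-1-yl in place of chloro on a saturated chain carbon bound to a carbonyl carbon. Among the measured compounds shown here, the one measured step that bears on it is the reverse of this site: a 2.9-fold lower number from compound 2 to compound 3 (0.47 log units; beyond the scatter). Since chloro now leaves, the expected step for compound 4, a 2.6-fold higher number from compound 3 to compound 4 (0.42 log units; beyond the scatter), points upward, back toward the numbers of compound 1 and compound 2, which both carry no chloro at that carbon. Compound 4 is therefore estimated at 45000 nM, with a range from 15000 nM to 110000 nM.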

Compound 4, half-maximal cytotoxic concentration: 15000 nM
The estimate for compound 4 lay 3.0-fold (0.48 log units) above the measured number, within the range that was stated.
By their numbers in this assay, from the lowest: compounds 4 and 3 (each within the scatter of the next); then compounds 2 and 1 (each within the scatter of the next).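

Pyrrolidin-1-yl in place of chloro on this saturated chain carbon leaves the number in this assay within the scatter (a 1.1-fold lower number from compound 3 to compound 4 (0.05 log units; within the scatter)), so the fall seen with chloro is not peculiar to chloro among the groups shown. Pyrrolidin-1-yl in place of hydrogen at the same carbon likewise gives a lower number (a 3.3-fold lower number from compound 2 to compound 4 (0.52 log units; beyond the scatter)). Hydrogen in place of methyl on the aromatic nitrogen also lowers the number (a 4.3-fold lower number from compound 1 to compound 4 (0.64 log units; beyond the scatter)), so this second site counts too. No evidence at hand explains these steps. Going by these compounds, it remains open whether an open-chain amine such as dimethylamino at this carbon would stay this low, and whether methyl on the aromatic nitrogen would raise the number with chloro in place.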